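Swapping 2-methylphenyl for 4-phenylphenyl on the carbonyl carbon

The source may hold more compounds than are shown below. What is called first, only, known or untested is meant among the compounds shown, and "the series" means these compounds.

Compound 1 (`CCCC(C)Oc1ccc(C(=O)/C=C/c2c(/C=C/c3ccc(OC)cc3)cc(OC)cc2OC)cc1`) and compound 2 (`COc1ccc(/C=C/c2cc(OC)cc(OC)c2/C=C/C(=O)c2ccccc2C)cc1`) share a core and differ only in the group on the carbonyl carbon. In a functional assay on HepG2 cells (Homo sapiens) for antiproliferative activity, read by MTT assay, with a stated time of 48 h (a lower number here means a stronger inhibitor, a higher number a weaker inhibitor), compound 1 gives 11.1 ug/mL and compound 2 gives 5.3 ug/mL as the lower of the two numbers. Compound 3 (`COc1ccc(/C=C/c2cc(OC)cc(OC)c2/C=C/C(=O)c2ccc(-c3ccccc3)cc2)cc1`) has not yet been measured. It puts 4-phenylphenyl in place of 2-methylphenyl on the carbonyl carbon (4-phenylphenyl in place of 2-methylphenyl on a carbonyl carbon). Within the data shown here, only one measured step bears on this change, and it is modest: a 2.1-fold lower number from compound 1 to compound 2 (0.32 log units; beyond the scatter) when 2-methylphenyl replaces 4-(1-methylbutoxy)phenyl. The entering 4-phenylphenyl looks more like the group of compound 1 than like 2-methylphenyl, so part of that step may be undone. Among the measured compounds shown here, this is thin evidence, since no measured compound carries 4-phenylphenyl. A modest step toward a higher number is therefore expected in this assay and may be no larger than that single measured step. The expected change is a 2.1-fold higher number from compound 2 to compound 3 (0.32 log units; beyond the scatter) on this estimate. For compound 3 the estimated value is 11 ug/mL with an expected range from 4.5 ug/mL to 25 ug/mL in repeated measurements.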

Compound 3, half-maximal inhibitory concentration: 10.5 ug/mL
Compound 3: the middle estimate sits 1.0-fold (0.02 log units) above what was measured; measured number inside the range.
By their numbers in this assay, from the lowest: compounds 2, 3 and 1 (each within the scatter of the next, the first and the last beyond it).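

On the carbonyl carbon, the change to 4-phenylphenyl, which brings a second aromatic ring, gives in this assay a step (a 2.0-fold higher number from compound 2 to compound 3 (0.30 log units; within the scatter)) that lies just within the scatter, so this much extra carbon on that position produces no readable difference from 2-methylphenyl. The other comparison, with phenyl in place of 1-methylbutoxy on an aromatic carbon (a 1.1-fold lower number from compound 1 to compound 3 (0.02 log units; within the scatter)), also lies within the scatter, so an aromatic ring and a branched ether chain read alike at this place. Compound 3 is therefore not separated from either neighbour, even though compound 1 and compound 2 are separated from each other, and nothing in the data explains these numbers.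

The compounds shown carry only carbon-rich groups and one ether at this position, which leaves open whether an amine or a carboxylic acid on the phenyl ring attached to the carbonyl carbon would move the number clearly in either direction. Also open, going by these compounds, is how a plain unsubstituted phenyl on the carbonyl carbon would compare with 2-methylphenyl, which would show whether the methyl group itself matters.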